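Carbamate in place of methyl on the shared core

A few compounds are considered here, and "the series" means these few. Any claim that something is new, unique, unknown or untested is made for them only; others in the source may bear on it.

This account follows a single change on the core of compound 3 `Cc1ncc(-c2ccccc2)c(C(C)(C)C)n1`. In a functional assay on the whole organism for inhibition, with Rattus norvegicus as the target, with stated times of 1 h and 3.5 h, at a dose of 100 mg/kg by the oral route (on this read-out higher numbers stand for more inhibition at the one dose given (going by the name of the read-out) and lower numbers for less inhibition), compound 3 gives 22%, the lowest of the three numbers recorded. Compound 1 `Cc1cnc(N)nc1-c1ccccc1` carries an amino group where compound 3 has a methyl, and compound 1 gives 34%; compound 2 `CN1CCc2ncncc2C1`, built on a different core, gives 50%. The unmeasured compound 4 `CCOC(=O)Nc1ncc(-c2ccccc2)c(C(C)(C)C)n1` differs from compound 3 in one place: (ethoxycarbonyl)amino in place of methyl on an aromatic carbon. Among the compounds with values here, no measured pair shows this change, so its size is open. Compound 4 is expected to shift by a number 8 percentage points higher from compound 3 to compound 4 (within the scatter), a rise that may stay within the scatter, since compound 1 with its amino group at the same place gives 34%. Compound 4 is therefore estimated at 30%, between 10% and 55%.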

Compound 4, a percentage reported as inhibition, in the whole organism at one dose (the size of the read-out at that dose, not a potency): 24%
The estimate for compound 4 lay 6 percentage points above the measured number; measured number inside the range.
By their numbers in this assay, from the lowest: compounds 3, 4 and 1 (each within the scatter of the next, the first and the last beyond it); then compound 2.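

In this assay, the step gives a number 2 percentage points higher from compound 3 to compound 4 (within the scatter) as (ethoxycarbonyl)amino replaces methyl on the aromatic carbon between two ring nitrogen atoms. This position on the shared core therefore accepts a group of 6 heavy atoms, with a hydrogen-bond donor and hydrogen-bond acceptors, without a change in this read-out beyond the scatter. No measurement offered here gives a reason for this result.

Going by these compounds, it remains open whether a free amino group at this position on the shared core would leave the read-out unchanged. The same holds for a longer chain in place of the ethyl of the carbamate.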